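Trimming a methoxy from the carbonyl-side aryl of compound 3

The source may report more compounds than this note shows. Statements on the series, on what has been measured and on what is new or still open speak of the compounds shown alone.

Three chalcone-like compounds sharing one core have been measured in an ADME assay on HEK293 cells (Homo sapiens) for antiproliferative activity, read by MTT assay, with a stated time of 24 h; a higher number here means a weaker inhibitor, a lower number a stronger inhibitor. Compound 1 `COc1ccc(-c2cc(/C=C/C(=O)c3cc(OC)c(OC)c(OC)c3)nc3cc(-c4ccccc4)nn23)cc1OC` gives 35000 nM, compound 2 `COc1ccc(C(=O)/C=C/c2cc(-c3cc(OC)c(OC)c(OC)c3)n3nc(-c4ccccc4)cc3n2)cc1OC` gives 81700 nM, and compound 3 `COc1ccc(C(=O)/C=C/c2cc(-c3ccc(OC)c(OC)c3)n3nc(-c4ccccc4)cc3n2)cc1OC` gives 32500 nM. Compound 3 holds the lowest of the three numbers, although its separation from compound 1 is within the scatter, while the step of a 2.5-fold lower number from compound 2 to compound 3 (0.40 log units; beyond the scatter) is beyond it.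

Compound 4 `COc1ccc(C(=O)/C=C/c2cc(-c3ccc(OC)c(OC)c3)n3nc(-c4ccccc4)cc3n2)cc1` is the next compound to be tested; it differs from compound 3 by hydrogen in place of methoxy on an aromatic carbon, the methoxy being removed from the (3,4-dimethoxyphenyl)carbonyl to leave a (4-methoxyphenyl)carbonyl. Two earlier steps of the same kind exist, both on the other aryl group: a 1.1-fold lower number from compound 1 to compound 3 (0.03 log units; within the scatter) and a 2.5-fold lower number from compound 2 to compound 3 (0.40 log units; beyond the scatter). One was flat and the other modestly lowering, so a small step, if any, toward a lower number is expected for compound 4 in this assay, estimated as a 1.3-fold lower number from compound 3 to compound 4 (0.11 log units; within the scatter). Compound 4 is therefore expected to give 25000 nM, within a range from 10000 nM to 60000 nM.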

Compound 4, half-maximal inhibitory concentration: 40000 nM
Compound 4: middle estimate off by 1.6-fold (0.20 log units), on the low side; low and high end bracket the measured number.
By their numbers in this assay, from the lowest: compounds 3, 1 and 4 (each within the scatter of the next); then compound 2.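

In this assay the carbonyl-side aryl group proves to be a place where trimming leaves the reading inside the scatter: the change from (3,4-dimethoxyphenyl)carbonyl to (4-methoxyphenyl)carbonyl gives a 1.2-fold higher number from compound 3 to compound 4 (0.09 log units; within the scatter) and does not separate the pair. The larger cut, 4-methoxyphenyl in place of 3,4,5-trimethoxyphenyl on a carbonyl carbon, gives a 1.1-fold higher number from compound 1 to compound 4 (0.06 log units; within the scatter) and also stays inside it, so the three forms of this aryl group in compound 1, compound 3 and compound 4 cannot be told apart here. Going by these compounds, whether replacing the methoxy that remains on compound 4 with an amine or a carboxylic acid would give a step beyond the scatter stays open. The compounds shown also come with no measurement that could explain these readings.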